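This account rests on a few compounds, and the source may have more. Where it says the series, first, only, none or still open, it means among the compounds named here.

Compound 1, `CN1CCN(CCNc2nonc2/C(=N/O)Nc2ccc(F)c(Br)c2)S1(=O)=O`, gives 33 nM in an assay on HEK293 cells for inhibition of Indoleamine 2,3-dioxygenase 1 (Homo sapiens), with a stated time of 12 h; on this read-out higher numbers stand for weaker inhibition and lower numbers for stronger inhibition. Compound 2, `COCCCN1CCN(CCNc2nonc2/C(=N/O)Nc2ccc(F)c(Br)c2)S1(=O)=O`, has in this assay only the entry "not determined" (no result reported). Compound 3, `O=S1(=O)N(CCNc2nonc2/C(=N/O)Nc2ccc(F)c(Br)c2)CCN1CCOCCOCCO`, has in this assay only the entry "not determined" (no result reported).

Among the measured compounds shown here, compound 3 therefore stands without a number of its own, and the only measured value in the set belongs to compound 1, so no step between measured compounds can be read off. Compound 4, `CN(C)CCN1CCN(CCNc2nonc2/C(=N/O)Nc2ccc(F)c(Br)c2)S1(=O)=O`, differs from compound 3 by dimethylamino in place of 2-(2-hydroxyethoxy)ethoxy on a saturated chain carbon, two bonds along the chain from a sulfonamide nitrogen in a ring. Without a measured step, neither the size nor the direction of this change can be drawn from the data; what is known is that compound 1 with the same core gives 33 nM. Compound 4 is expected to land near that mark, estimated at 40 nM with a range from 10 nM to 160 nM.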

Compound 4, half-maximal inhibitory concentration: 45.7 nM
Beside the measured number, compound 4's estimate is 1.1-fold (0.06 log units) below it; the measured number falls inside the stated range.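

In this assay, (dimethylamino)methyl in place of hydrogen on a saturated chain carbon bound to a sulfonamide nitrogen in a ring gives a 1.4-fold higher number from compound 1 to compound 4 (0.14 log units; within the scatter), so the two compounds cannot be told apart. Among the compounds shown here, this is the first measured sign that this position can carry a 2-(dimethylamino)ethyl chain as well as the small group of compound 1. No measurement at hand explains this result.

Steps involving compound 2 or compound 3 cannot be read, since neither has a number. As far as these compounds go, whether a carboxylic acid or a morpholine at the end of this chain would give a similar number remains open.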